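This account rests on a few compounds, and the source may have more. Where it says the series, first, only, none or still open, it means among the compounds named here.

Of the compounds shown here, three have been tested in a functional assay on M14 cells (Homo sapiens) for cytotoxicity, read by sulforhodamine B assay, with a stated time of 48 h (a higher number here means that more compound is tolerated, a lower number that less compound is tolerated), and a fourth awaits measurement. Compound 3 `ClCc1ccc(Cn2cnc3c(Cl)nc(Cl)nc32)cc1` gives 53700 nM. Compound 2 `ClCc1cccc(Cn2cnc3c(Cl)nc(Cl)nc32)c1` has the same atoms as compound 3 joined differently, and the difference between the two cores is not broken down here; compound 2 gives 6450 nM, the lowest of the two numbers. Compound 1 `Nc1nc(Cl)c2ncn(Cc3ccc(CCl)cc3)c2n1` reaches only a limit of the assay, > 100000 nM. Compound 1 arises from compound 3 by one change, (amino in place of chloro on an aromatic carbon), and the step of an at least 1.8-fold higher number from compound 3 to compound 1 (0.27 log units; that floor lies within the scatter) is a floor rather than a number because of the limit of > 100000 nM in this assay, at which 1 of the 3 values shown sits. The same change, (amino in place of chloro on an aromatic carbon), turns compound 2 into compound 4 `Nc1nc(Cl)c2ncn(Cc3cccc(CCl)c3)c2n1`, which has yet to be measured in this assay. Resting on the step of an at least 1.8-fold higher number from compound 3 to compound 1 (0.27 log units; that floor lies within the scatter), whose true size is hidden by the limit, compound 4 is expected to tolerate more compound than compound 2, with an estimated step of a 4.7-fold higher number from compound 2 to compound 4 (0.67 log units; beyond the scatter). Compound 4 is therefore estimated at 30000 nM, likely between 8000 nM and 150000 nM.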

Compound 4, concentration lethal to 50% of the cells: 41700 nM
The estimate for compound 4 lay 1.4-fold (0.14 log units) below the measured number, and the stated range covers the measured number.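

On the core of compound 2, amino in place of chloro on an aromatic carbon gives a 6.5-fold higher number from compound 2 to compound 4 (0.81 log units; beyond the scatter) in this assay, a step that can be read in full. Set beside the same change on the other core, this step points the same way, but its size cannot be matched against the earlier one: the same change on two cores in this assay, an at least 1.8-fold higher number (0.27 log units; that floor lies within the scatter) from compound 3 to compound 1 and a 6.5-fold higher number (0.81 log units; beyond the scatter) from compound 2 to compound 4; the limit leaves it open whether they differ. The series therefore shows the change carried from one core to another only in direction, with the earlier step a floor within the scatter, and it does not show that the size carries over: the limit of > 100000 nM in this assay, at which 1 of the 4 values shown sits.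

On these data alone, it remains open whether a methylamino or a methoxy group on the same carbon, between two ring nitrogen atoms, would shift the number as amino does. Also open, as far as these compounds go, is whether the step would hold on cores that carry a hydroxymethyl or bromomethyl group in place of the chloromethyl group.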